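A few compounds are considered here, and "the series" means these few. Any claim that something is new, unique, unknown or untested is made for them only; others in the source may bear on it.

Measured in a functional assay on NCI/ADR-RES cells (Homo sapiens) for inhibition; on this read-out higher numbers stand for weaker inhibition of growth and lower numbers for stronger inhibition of growth:
Compound 1 `O=S(=O)(/C=C/c1ccccc1)Cc1ccc(Nc2ncnc3ccccc23)cc1`: > 100000 nM, a limit
Compound 2 `N#Cc1ccc(/C=C/S(=O)(=O)Cc2ccc(Nc3ncnc4ccccc34)cc2)cc1`: > 100000 nM, a limit

For compound 2 the reading of > 100000 nM is a limit and not a number. Neither measured compound has yet given a number, and both stand at the same place: the limit of > 100000 nM in this assay, at which 2 of the 2 values shown sit.

The next compound, compound 3 `O=S(=O)(/C=C/c1ccc(Cl)c(Cl)c1)Cc1ccc(Nc2ncnc3ccccc23)cc1`, keeps the shared core and changes one group: 3,4-dichlorophenyl in place of 4-cyanophenyl on a double-bonded chain carbon bound to a double-bonded chain carbon. Here 3,4-dichlorophenyl stands in place of 4-cyanophenyl on a double-bonded chain carbon bound to a double-bonded chain carbon.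

For the measured compounds named here, the one measured step that touches this group is a step that the two limits leave unreadable from compound 1 to compound 2, in which cyano replaces hydrogen on an aromatic carbon. It offers no size to carry forward, so any forecast here is weakly grounded. Only a small move in this assay towards stronger inhibition of growth is expected, and another limit is the likeliest result.

The expected size of the change is an at least 1.4-fold lower number from compound 2 to compound 3 (0.15 log units; that floor lies within the scatter). For compound 3 the estimate is 70000 nM, with an expected range of 15000 nM to 100000 nM.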

Compound 3, concentration for 50% growth inhibition: 22000 nM
The estimate for compound 3 lay 3.2-fold (0.50 log units) above the measured number; low and high end bracket the measured number.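

In this assay, compound 3 is the only one of the compounds shown to give a number rather than a limit, so the group on a double-bonded chain carbon bound to a double-bonded chain carbon can move this read-out. Putting 3,4-dichlorophenyl in place of 4-cyanophenyl gives an at least 4.5-fold lower number from compound 2 to compound 3 (0.65 log units; beyond the scatter), and putting it in place of phenyl gives an at least 4.5-fold lower number from compound 1 to compound 3 (0.65 log units; beyond the scatter); each size is only a floor, as the starting compound in each step has a limit and not a number. The step from compound 1 to compound 2 cannot be read, so the comparison rests on one compound that moved away from a shared reading: the limit of > 100000 nM in this assay, at which 2 of the 3 values shown sit.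

The compounds shown leave open whether both chlorine atoms are needed, which a 3-chlorophenyl or a 4-chlorophenyl group at the same place would begin to answer. Going by these compounds, it is also open whether the change depends on chlorine itself or would also appear with other groups on this ring, such as a methoxy group or an amine.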